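A Chloro Shift on the Urea, Seen Twice

This account rests on a few compounds, and the source may have more. Where it says the series, first, only, none or still open, it means among the compounds named here.

Compound 1, `CN(C)CCCNc1nc(-c2ccc(NC(=O)Nc3ccc(Cl)cc3)cc2)nc2c(Cl)c(Cl)sc12`: 330 nM
Compound 2, `CN(C)CCCNc1nc(-c2ccc(NC(=O)Nc3ccccc3Cl)cc2)nc2c(Cl)c(Cl)sc12`: 820 nM
Compound 3, `CCN(CC)CCCNc1nc(-c2ccc(NC(=O)Nc3ccc(Cl)cc3)cc2)nc2ccsc12`: 58 nM

All three compounds were tested in a functional assay on HT-29 cells (Homo sapiens) for cytotoxicity, read by MTT assay, with a stated time of 72 h; a lower number here means a stronger inhibitor, a higher number a weaker inhibitor. Compound 1 gives 330 nM and compound 2 gives 820 nM. The change between them is 2-chlorophenyl in place of 4-chlorophenyl on an amide-type nitrogen, and that change made the step of a 2.5-fold higher number from compound 1 to compound 2 (0.40 log units; beyond the scatter). Compound 3, which gives 58 nM, has the lowest number of the three; compound 1 lies nearest to it and compound 2 furthest. How the core of compound 3 differs from the core of compound 1 is not broken down here.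

Compound 4, `CCN(CC)CCCNc1nc(-c2ccc(NC(=O)Nc3ccccc3Cl)cc2)nc2ccsc12`, has not yet been measured in this assay. It differs from compound 3 by 2-chlorophenyl in place of 4-chlorophenyl on an amide-type nitrogen. Within the data shown here, this is the same change as the one from compound 1 to compound 2, and the place is described in the same words for both pairs, so it is taken as the same change on a different core.

For compound 4 the expected step is a 2.5-fold higher number from compound 3 to compound 4 (0.40 log units; beyond the scatter). Among the measured compounds shown here, that expectation rests on the single measured step of a 2.5-fold higher number from compound 1 to compound 2 (0.40 log units; beyond the scatter), and on nothing else, since no other pair shows the change. Whether the second core answers the change in the same way is not known, so the range is kept wide. Compound 4 is estimated at 145 nM in this assay, expected to fall between 60 nM and 350 nM.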

Compound 4, half-maximal inhibitory concentration: 340 nM
Estimate against measurement, compound 4: 2.3-fold (0.37 log units) below; measured number inside the range.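

On the second core the change repeated what it had done on the first: in this assay, 2-chlorophenyl in place of 4-chlorophenyl on an amide-type nitrogen gave a 5.9-fold higher number from compound 3 to compound 4 (0.77 log units; beyond the scatter). Both steps point the same way, and their sizes cannot be told apart: the same change on two cores in this assay, a 2.5-fold higher number (0.40 log units; beyond the scatter) from compound 1 to compound 2 and a 5.9-fold higher number (0.77 log units; beyond the scatter) from compound 3 to compound 4, 2.4-fold (0.37 log units) apart, within the scatter of two such steps. Among these compounds, for this series, this shows that the change carried over from the core of compound 1 to the core of compound 3 in direction and, within the scatter, in size, but it rests on only two pairs and does not show that the change would behave alike on any further core, nor does it explain why the number rises.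

The compounds shown leave open whether the step belongs to the chlorine itself or would look the same with a methyl, a methoxy or a trifluoromethyl group on the phenyl ring in its place. They also leave open how the dimethylamino and diethylamino ends and the chlorines on the core of compound 1 each bear on the numbers, and whether a morpholine or a longer chain at the amine end would alter the response to this change.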